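The source may report more compounds than this note shows. Statements on the series, on what has been measured and on what is new or still open speak of the compounds shown alone.

Working notes on the series.

Compound 3 `COc1ccc(CNc2nc3cc(N)cc(N)c3nc2-c2ccccc2)cc1OC` gives 6760 nM in a functional assay on OVCAR-8 cells (Homo sapiens) for inhibition, read by sulforhodamine B assay, with a stated time of 48 h (on this read-out higher numbers stand for weaker inhibition of growth and lower numbers for stronger inhibition of growth), the lowest number among the three measured compounds. Compound 2 `Nc1cc(N)c2nc(-c3ccccc3)c(Sc3ccc(F)cc3)nc2c1` gives 16600 nM and compound 1 `Nc1cc(N)c2nc(-c3ccccc3)c(Oc3ccc(Cl)c(Cl)c3)nc2c1` gives 28200 nM; both gaps to compound 3 are beyond the scatter, so compound 3 is the strongest inhibitor of growth measured so far. For the measured compounds named here, the one single-point step available, a 1.7-fold lower number from compound 1 to compound 2 (0.23 log units; within the scatter), swaps one aryl group for another on the shared core and stays within the scatter.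

Compound 4 `Nc1cc(N)c2nc(-c3ccccc3)c(NCc3ccc(F)cc3)nc2c1` differs from compound 3 by 4-fluorophenyl in place of 3,4-dimethoxyphenyl on a saturated chain carbon bound to a nitrogen on an aromatic ring. Going by the values given here, no measured step exchanges the aryl group on the saturated chain carbon bound to the ring nitrogen, so the only guide is the aryl swap from compound 1 to compound 2, which hardly moved the number. A step of comparable size, or none beyond the scatter, is therefore expected; a modest rise in the number is allowed for because the substituent pattern that goes with the lowest value in compound 3 6760 nM is removed. Compound 4 is expected to give 10000 nM in this assay, between 4000 nM and 25000 nM, a step of a 1.5-fold higher number from compound 3 to compound 4 (0.17 log units; within the scatter).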

Compound 4, concentration for 50% growth inhibition: 2630 nM
The estimate for compound 4 lay 3.8-fold (0.58 log units) above the measured number; measured number outside the range, below it.
By their numbers in this assay, from the lowest: compound 4; then compound 3; then compounds 2 and 1 (each within the scatter of the next).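

In this assay the aryl group on the saturated chain carbon bound to a nitrogen on an aromatic ring clearly matters: 4-fluorophenyl in place of 3,4-dimethoxyphenyl gives a 2.6-fold lower number from compound 3 to compound 4 (0.41 log units; beyond the scatter) and leaves compound 4 as the strongest inhibitor of growth of the four. For the compounds shown here, on the aromatic carbon of the shared core, (4-fluorobenzyl)amino in place of (4-fluorophenyl)sulfanyl gives a 6.3-fold lower number from compound 2 to compound 4 (0.80 log units; beyond the scatter) and in place of 3,4-dichlorophenoxy gives an 11-fold lower number from compound 1 to compound 4 (1.03 log units; beyond the scatter) (a change of larger size than the one earlier step). The data shown offer nothing that explains these steps.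

Going by these compounds alone, whether the gain at the chain position comes from the fluorine or from the loss of the two methoxy groups stays open, since the one step changes both. Also open, on these data alone, is how a longer chain in place of the saturated chain carbon, or an amine on the aryl ring, would change the number.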